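Benzoxazolyl amide in place of acetylphenyl on a hydrate chain

This account rests on a few compounds, and the source may have more. Where it says the series, first, only, none or still open, it means among the compounds named here.

Going by the values given here, compound 2 `CC(=O)c1ccc(NC(=O)CCCCCCNC(=O)C(O)(O)C(F)(F)F)cc1` is the only member of the series that returns a number in a functional assay on HCT-116 cells (Homo sapiens) for inhibition, read by colorimetric assay, with a stated time of 3 days; a higher number here means a weaker inhibitor, a lower number a stronger inhibitor: compound 2 gives 12100 nM. Compound 1 `O=C(CCCCNC(=O)c1cc(=O)c(O)co1)Nc1ccccc1` sits at a limit of this assay, > 100000 nM, and is not a number. Compound 3 `CC(=O)C(=O)NCCCCCCC(=O)Nc1ccccc1` likewise returns only the limit > 100000 nM. Among the compounds with values here, two of the three values therefore rest at the limit of > 100000 nM in this assay, at which 2 of the 3 values shown sit, and no step between measured compounds can be read. Compound 4 `O=C(CCCCCCNC(=O)C(O)(O)C(F)(F)F)Nc1nc2ccccc2o1` is not yet measured; it differs from compound 2 by 1,3-benzoxazol-2-yl in place of 4-acetylphenyl on an amide-type nitrogen. Within the data shown here, no measured pair speaks to this change, so the expected step of a 1.3-fold lower number from compound 2 to compound 4 (0.13 log units; within the scatter) is taken as small, within the usual scatter, in no fixed direction. Compound 4 is therefore estimated at 9000 nM in this assay, between 2500 nM and 40000 nM.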

Compound 4, half-maximal inhibitory concentration: 3450 nM
Compound 4: the middle estimate sits 2.6-fold (0.42 log units) above what was measured; low and high end bracket the measured number.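

In this assay, going by these compounds alone, the change on the amide-type nitrogen gives the only readable step: a 3.5-fold lower number from compound 2 to compound 4 (0.54 log units; beyond the scatter). With the rest of compound 2 held fixed, this position responds modestly to the exchange of 4-acetylphenyl for 1,3-benzoxazol-2-yl. Steps involving compound 1 or compound 3 cannot be read: the limit of > 100000 nM in this assay, at which 2 of the 4 values shown sit.

Which part of the 1,3-benzoxazol-2-yl group carries the step remains open. Going by these compounds, it is also open how a 1,3-benzothiazol-2-yl group or a plain phenyl group would read on this chain.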